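The compounds below may be only part of what the source reports. "The series", "measured", "known", "first", "only" and "open" are said of these compounds alone.

Measured so far in a functional assay; a higher number here means a weaker inhibitor, a lower number a stronger inhibitor:
compound 1 `N#CC1=C(N)OC(c2c[nH]c3ccccc23)=C(C#N)C1c1ccc(F)cc1` gives 960 ug/mL.
compound 3 `COc1cc(Br)c(C2C(C#N)=C(N)OC(c3c[nH]c4ccccc34)=C2C#N)cc1OC` gives 880 ug/mL.
compound 2 `N#CC1=C(N)OC(c2c[nH]c3ccccc23)=C(C#N)C1c1ccccc1Cl` gives > 1000 ug/mL, which is a limit of the assay and not a number.

Compound 1 holds the higher of the two numbers in this assay; compound 3 sits within the scatter of it, so the two are not told apart. The third value, that of compound 2, is only a limit (the limit of > 1000 ug/mL in this assay, at which 1 of the 3 values shown sits).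

Compound 4 `COc1ccc(C2C(C#N)=C(N)OC(c3c[nH]c4ccccc34)=C2C#N)cc1OC` is not yet measured. It differs from compound 1 by 3,4-dimethoxyphenyl in place of 4-fluorophenyl on a saturated ring carbon. Within the data shown here, one measured step touches the same position: an at least 1.0-fold higher number from compound 1 to compound 2 (0.01 log units; that floor lies within the scatter), which shows no change that rises above the scatter. Compound 3, which also carries the two methoxy groups on that phenyl, has a number within the scatter of compound 1. Neither observation points to a shift in either direction, so compound 4 is expected to stay close to compound 1, with an estimated step of a 1.1-fold lower number from compound 1 to compound 4 (0.03 log units; within the scatter). The estimate for compound 4 in this assay is therefore 900 ug/mL, with a range from 450 ug/mL to 1800 ug/mL.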

Compound 4, half-maximal inhibitory concentration: 867 ug/mL
The estimate for compound 4 lay 1.0-fold (0.02 log units) above the measured number, and the stated range covers the measured number.
By their numbers in this assay, from the lowest: compounds 4, 3 and 1 (each within the scatter of the next). At a limit, above all of these: compound 2.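

In this assay, among these compounds, the change to 3,4-dimethoxyphenyl gives a 1.1-fold lower number from compound 1 to compound 4 (0.04 log units; within the scatter), the first step at this position that does not rest on a limit: on the saturated ring carbon, this group, with its two hydrogen-bond acceptors, is not told apart from 4-fluorophenyl. Among the compounds shown here, the bromo on that phenyl is also read on its own for the first time, with a 1.0-fold lower number from compound 3 to compound 4 (0.01 log units; within the scatter), and is not told apart from hydrogen. Compound 2 holds only a limit: the limit of > 1000 ug/mL in this assay, at which 1 of the 4 values shown sits. The step that rests on this limit is an at least 1.1-fold lower number from compound 2 to compound 4 (0.06 log units; that floor lies within the scatter), and it leaves open how large the change is.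

All groups shown at this position are substituted phenyls, and no readable step rises above the scatter. From the compounds shown here alone, whether a phenyl carrying a carboxylic acid, or an amine on a longer chain in its place, would move the number beyond the scatter remains open.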